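A few compounds are considered here, and "the series" means these few. Any claim that something is new, unique, unknown or untested is made for them only; others in the source may bear on it.

Measured compounds in this set:

- compound 1, `CCN(CC)S(=O)(=O)c1ccc(NC(=O)c2ccccc2)c2ccccc12`: > 30000 nM
- compound 2, `Cc1ccccc1C(=O)Nc1ccc(S(=O)(=O)NC2CCN(C(=O)C3CCCC3)CC2)c2ccccc12`: 9.1 nM

In an assay on L1.2 cells for binding affinity to C-C chemokine receptor type 8 (Homo sapiens) (a lower number here means a stronger inhibitor, a higher number a weaker inhibitor), compound 1 gives > 30000 nM, which is a limit of the assay and not a number; it is the limit described as the limit of > 30000 nM in this assay, at which 1 of the 2 values shown sits. Going by the values given here, compound 2 gives 9.1 nM in this assay and is thus the only compound of the two with a numerical value, so there is no measured step against which to set expectations.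

The next compound, compound 3 with structure `Cc1ccccc1C(=O)Nc1ccc(S(=O)(=O)NC2CCN(C(=O)N3CCCCC3)CC2)c2ccccc12`, keeps the whole of compound 2 apart from one change: piperidin-1-yl in place of cyclopentyl on a carbonyl carbon. The same difference, cut one bond further out, reads cyclopentylcarbonyl to (piperidin-1-yl)carbonyl; the amide-type nitrogen in a ring that carries the carbonyl is unchanged.

Among the compounds with values here, with no measured step available, the change is expected to stay within the usual scatter or to move the value only slightly toward weaker binding. For compound 3 the expected value in this assay is 14 nM, in the range 4 nM to 45 nM, meaning an expected step of a 1.5-fold higher number from compound 2 to compound 3 (0.19 log units; within the scatter).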

Compound 3, inhibition constant: 4.2 nM
Compound 3: middle estimate off by 3.3-fold (0.52 log units), on the high side, and the stated range covers the measured number.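

In this assay, going by these compounds alone, the step of a 2.2-fold lower number from compound 2 to compound 3 (0.34 log units; beyond the scatter) is the only measured change in one place so far, and it shows that the carbonyl carbon on the ring nitrogen of the piperidine can carry piperidin-1-yl as well as cyclopentyl without any loss of binding. The step is modest, but it gives this position a direction: the group with a nitrogen on the carbonyl carbon and a six-membered ring reads better than the five-membered carbon ring. The change alters the ring size and the atom attached to the carbonyl carbon in a single move, and nothing measured here offers a reason for the step.

The compounds shown leave open whether the difference follows the ring nitrogen or the extra ring atom, a question that cyclohexyl and pyrrolidin-1-yl on the same carbonyl carbon would separate. Also open, going by these compounds, is whether a ring is needed at all at this place, as a dimethylamino group would show, and how a further hetero atom in the ring, as in morpholin-4-yl, would read in this assay.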